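The source may hold more compounds than are shown below. What is called first, only, known or untested is meant among the compounds shown, and "the series" means these compounds.

Working notes on the quinoline pair. In a functional assay on Hep2C cells (Homo sapiens) for antiproliferative activity, read by MTT assay, with a stated time of 24 h (on this read-out higher numbers stand for weaker inhibition and lower numbers for stronger inhibition), compound 2 `COc1ccc2nc(-c3ccccc3)cc(-c3ccccc3)c2c1` gives 496000 nM, the higher of the two numbers available; compound 1 `Clc1ccc(-c2cc(-c3ccccc3)c3cc(Br)ccc3n2)cc1` gives 269000 nM in this assay, and the gap between the two lies within the scatter, so no order between them is claimed. Compound 3 `Brc1ccc2nc(-c3ccccc3)cc(-c3ccccc3)c2c1` has not yet been measured in this assay. It differs from compound 2 by bromo in place of methoxy on an aromatic carbon; the bromo in compound 3 sits at the same position on the core as in compound 1, while the two phenyl groups of compound 2 are kept. With no directly measured step of this kind in the set, and both measured values in this assay sitting close together, compound 3 is expected to land near both, with a step from compound 2 to compound 3 of a 1.4-fold lower number from compound 2 to compound 3 (0.15 log units; within the scatter) that is not expected to exceed the scatter. The expected value for compound 3 in this assay is 350000 nM, with a range from 150000 nM to 800000 nM.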

Compound 3, half-maximal inhibitory concentration: 128000 nM
For compound 3 the middle estimate is 2.7-fold (0.44 log units) above the measured one; measured number below the stated range.
By their numbers in this assay, from the lowest: compound 3; then compounds 1 and 2 (each within the scatter of the next).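

The bromo-for-methoxy change on this aromatic carbon, meta to a fused ring and para to a fused ring, now has a readable effect in this assay: a 3.9-fold lower number from compound 2 to compound 3 (0.59 log units; beyond the scatter), a modest step beyond the scatter, where the values of compounds 1 and 2 alone gave no order. With bromo held in place, hydrogen in place of chloro on an aromatic carbon gives a 2.1-fold lower number from compound 1 to compound 3 (0.32 log units; beyond the scatter), also modest and beyond the scatter, so this second site also registers a change. No measurement at hand accounts for either step.

As far as these compounds go, with only methoxy and bromo compared at this position, the reach of the effect is unknown; an amine or a carboxylic acid there could fall on either side of compound 3. From the compounds shown here alone, whether the chloro step would hold with methoxy in place of bromo also stays open.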